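Cyclohexyl in Place of Isopropyl: Expected Cytotoxicity of Compound 3

A few compounds are considered here, and "the series" means these few. Any claim that something is new, unique, unknown or untested is made for them only; others in the source may bear on it.

The compounds were compared in an ADME assay on CHO-K1 cells (Cricetulus griseus) for cytotoxicity, read by MTT assay, with a stated time of 24 h; a higher number here means a weaker inhibitor, a lower number a stronger inhibitor. Compound 1, `CCOC(=O)c1nc(C2CCCCC2)sc1-c1cccc(C#N)c1`, reaches only a limit of the assay, > 50 ug/mL. Compound 2, `CCOC(=O)c1nc(C(C)C)sc1-c1ccc(C#N)cc1`, gives 40.5 ug/mL in this assay. This is the only number shown among the two values; the value of compound 1 is a limit (the limit of > 50 ug/mL in this assay, at which 1 of the 2 values shown sits). Compound 3, `CCOC(=O)c1nc(C2CCCCC2)sc1-c1ccc(C#N)cc1`, has not yet been measured. It differs from compound 2 by cyclohexyl in place of isopropyl on an aromatic carbon. Among the measured compounds shown here, no step between measured compounds is recorded, so the size of such a change is not known from the data. Compound 3 is expected to give 50 ug/mL in this assay, within a range from 30 ug/mL to 85 ug/mL. The expected step is a 1.2-fold higher number from compound 2 to compound 3 (0.09 log units; within the scatter), a modest move toward weaker inhibition that may end at the limit, because compound 1 with its cyclohexyl sits at the limit of > 50 ug/mL in this assay, at which 1 of the 2 values shown sits.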

Compound 3, half-maximal inhibitory concentration: 75.2 ug/mL
Compound 3: middle estimate off by 1.5-fold (0.18 log units), on the low side; measured number inside the range.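

Among the compounds shown here, at the aromatic carbon next to the ring nitrogen and next to the ring sulfur, cyclohexyl in place of isopropyl gives the first step that can be read at this position: a 1.9-fold higher number from compound 2 to compound 3 (0.27 log units; within the scatter). With the 4-cyanophenyl group held in place, the six-membered carbon ring is therefore not separated from isopropyl in this assay, and a cyclohexyl compound now has a readable number. Compound 1 stands only at a limit, so the step that sets 4-cyanophenyl in place of 3-cyanophenyl cannot be read: the limit of > 50 ug/mL in this assay, at which 1 of the 3 values shown sits.

The compounds shown leave open whether any group at this position moves the number beyond the scatter, for instance an amine or a longer chain. They also leave open how the cyanophenyl position reads where both compounds give a number, and what a carboxylic acid in place of the ethoxycarbonyl group would do.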